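Sulfamoyl added to the phenyl of compound 2

A few compounds are considered here, and "the series" means these few. Any claim that something is new, unique, unknown or untested is made for them only; others in the source may bear on it.

Compound 1 `COc1cccc(F)c1-c1cccc2nc(N)oc12`: > 20000 nM
Compound 2 `COc1cccc(F)c1-c1cccc2nc(Nc3ccccc3)oc12`: > 20000 nM

In an assay on BAF cells for inhibition of ribosomal protein S6 kinase alpha-2 (Mus musculus) (a lower number here means a stronger inhibitor, a higher number a weaker inhibitor), compound 1 gives only a limit, > 20000 nM. In this assay compound 2 likewise gives only a limit, > 20000 nM. The step that the two limits leave unreadable from compound 1 to compound 2 is therefore not readable in size or direction. Both values sit at the same limit, (the limit of > 20000 nM in this assay, at which 2 of the 2 values shown sit). Where compound 2 stands is thus known only as a limit; no measured number places it within the range of this assay.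

Compound 3 `COc1cccc(F)c1-c1cccc2nc(Nc3cccc(S(N)(=O)=O)c3)oc12` differs from compound 2 by sulfamoyl in place of hydrogen on an aromatic carbon. Going by the values given here, the only measured step, the step from hydrogen to phenyl on the ring nitrogen, has no readable size, so no measured step bears on this change, and no expectation beyond the scatter can be drawn from the data in either direction.

Compound 3 is therefore expected to stay near the same limit, estimated at 20000 nM with a range of 3000 nM to 60000 nM.

The expected step of a number no higher from compound 2 to compound 3 (the limit leaves the size open) is taken as none beyond the scatter.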

Compound 3, half-maximal inhibitory concentration: > 20000 nM
Compound 3 ended at the assay's limit (the forecaster's own chance of this, stated with the estimate: 70%); the middle value lies on the limit itself.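

No new step can be read from compound 2 to compound 3, and both compounds give only a limit in this assay: the limit of > 20000 nM in this assay, at which 3 of the 3 values shown sit.

The compounds shown leave open how strongly any of them inhibits in this assay, and so what size and direction the change to sulfamoyl on the phenyl of compound 2 has.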